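An Open Diamine Chain Replaces the Aminocyclohexyl Ring

The compounds below may be only part of what the source reports. "The series", "measured", "known", "first", "only" and "open" are said of these compounds alone.

Measured so far, in an assay on HeLa cells for inhibition of sphingosine-1-phosphate transporter SPNS2 (Mus musculus), read by LC-MS, tested at 2 uM; on this read-out higher numbers stand for more inhibition at the one concentration tested (going by the name of the read-out) and lower numbers for less inhibition:
Compound 1 `CCCCCCCCCCc1ccc(-c2noc(CC3CNC3)n2)cc1` gives 63%.
Compound 2 `CCCCCCCCCCc1ccc(-c2noc([C@@H]3CCCN3)n2)cc1` gives 21%.
Compound 3 `CCCCCCCCCCc1ccc(-c2noc([C@@H]3CCC[C@@H](N)C3)n2)cc1` gives 13%.

Compound 3 stands lowest of the three: the step of a number 50 percentage points lower from compound 1 to compound 3 (beyond the scatter) is large, while the step of a number 8 percentage points lower from compound 2 to compound 3 (within the scatter) stays within the scatter, so compound 2 and compound 3 are not distinguishable. Compound 4 `CCCCCCCCCCc1ccc(-c2noc([C@@H](N)CCN)n2)cc1` carries a new group on the shared core: 1,3-diaminopropyl in place of 3-aminocyclohexyl on an aromatic carbon. Going by the values given here, no measured step swaps a ring for an open chain, so only the spread between compound 1 and the other two hints that this position can move the read-out strongly, in either direction. Compound 4 is therefore expected to give 30%, between 5% and 60%, an estimated step of a number 17 percentage points higher from compound 3 to compound 4 (beyond the scatter).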

Compound 4, a percentage reported as inhibition, at one concentration (the size of the read-out at that concentration, not a potency): 14%
The estimate for compound 4 lay 16 percentage points above the measured number; low and high end bracket the measured number.
By their numbers in this assay, from the lowest: compounds 3, 4 and 2 (each within the scatter of the next); then compound 1.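

In this assay, the open 1,3-diaminopropyl chain, which has no ring, reads the same as the ring-bearing groups: a number 1 percentage points higher from compound 3 to compound 4 (within the scatter) and a number 7 percentage points lower from compound 2 to compound 4 (within the scatter). A ring at this position is therefore not what separates these three compounds, whereas the (azetidin-3-yl)methyl group remains apart, with a number 49 percentage points lower from compound 1 to compound 4 (beyond the scatter). Nothing available explains that gap.

Still open, from the compounds shown here alone, is whether a piperidin-4-ylmethyl group or an azetidin-3-yl group without the connecting carbon would match compound 1. A carboxylic acid at this position also remains untested in the compounds shown.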